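Cytotoxicity notes: hydroxymethyl in place of amino

This account rests on a few compounds, and the source may have more. Where it says the series, first, only, none or still open, it means among the compounds named here.

Measured so far in a functional assay on MT2 cells (Homo sapiens) for cytotoxicity, read by MTT assay; a higher number here means that more compound is tolerated, a lower number that less compound is tolerated:
- compound 1, `CC(C)=CCOc1cc(Nc2ncccn2)ccc1Cl`, gives 2500 nM
- compound 2, `CC(C)=CCOc1cc(Nc2nccc(N)n2)ccc1Cl`, gives 500 nM

Within the data shown here, compound 2 stands at the lowest of the two numbers in this assay; its only neighbour is compound 1, and the step of a 5.0-fold lower number from compound 1 to compound 2 (0.70 log units; beyond the scatter) lies beyond the scatter, so less of compound 2 is tolerated than of compound 1.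

The next compound, compound 3, `CC(C)=CCOc1cc(Nc2nccc(CO)n2)ccc1Cl`, differs from compound 2 in one place: hydroxymethyl in place of amino on an aromatic carbon.

Among the measured compounds shown here, the only measured step that touches this carbon is a 5.0-fold lower number from compound 1 to compound 2 (0.70 log units; beyond the scatter), where amino replaced hydrogen. For the measured compounds named here, no step compares hydroxymethyl with amino, so the direction of the new change is not fixed by the data. Compound 3 is expected to fall between compound 2 and compound 1 in this assay, with the step of a 2.0-fold higher number from compound 2 to compound 3 (0.30 log units; within the scatter) estimated as a modest rise that may not exceed the scatter. For compound 3 the estimate is 1000 nM, within a range from 300 nM to 3500 nM.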

Compound 3, half-maximal cytotoxic concentration: 220 nM
Estimate against measurement, compound 3: 4.5-fold (0.66 log units) above, outside the stated range (below it).
By their numbers in this assay, from the lowest: compound 3; then compound 2; then compound 1.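

In this assay, this aromatic carbon next to the ring nitrogen proves sensitive to more than the introduction of amino: replacing amino with hydroxymethyl takes the number further down (a 2.3-fold lower number from compound 2 to compound 3 (0.36 log units; beyond the scatter)), and the comparison with the unsubstituted compound is larger still (an 11-fold lower number from compound 1 to compound 3 (1.06 log units; beyond the scatter)). Amino and hydroxymethyl are therefore not interchangeable here, even though each carries one hydrogen-bond donor and one hydrogen-bond acceptor, so those counts alone do not set the number across compound 2 and compound 3. Nothing available here accounts for the gap between hydroxymethyl and amino at this position.

The three compounds leave open whether the downward trend from hydrogen through amino to hydroxymethyl would extend to other groups on this carbon, such as a methoxymethyl ether, a longer hydroxyethyl chain or a carboxylic acid. They also leave open whether the hydroxyl hydrogen of hydroxymethyl matters, which a methoxymethyl or plain methyl group at the same carbon could test, and whether the same order holds on any cell type other than the one used here.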